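This account rests on a few compounds, and the source may have more. Where it says the series, first, only, none or still open, it means among the compounds named here.

Compound 1 `CN(C(=O)CNC(=O)CN)c1ccc(Cl)cc1C(=O)c1ccccc1Cl` is the stronger of the two measured compounds in a functional assay on the whole organism for antagonist activity, with Mus musculus as the target (on this read-out lower numbers stand for an effect already at smaller amounts and higher numbers for an effect only at larger amounts of compound), where compound 1 gives 0.58 mg/kg. Compound 2 `CN(C(=O)CNC(=O)c1ccccc1)c1ccc(Cl)cc1C(=O)c1ccccc1` gives 7.6 mg/kg in this assay, a higher number that lies beyond the scatter, so compound 1 holds the lowest number of the two. Compound 3 `CN(C(=O)CNC(=O)CN1CCN(c2ccccc2)CC1)c1ccc(Cl)cc1C(=O)c1ccccc1Cl` differs from compound 1 in one place: 4-phenylpiperazin-1-yl in place of amino on a saturated chain carbon bound to a carbonyl carbon. Within the data shown here, no measured pair shows a change of this kind, so its effect is uncertain. The step from compound 1 to compound 3 is expected to be modest and upward, a 2.6-fold higher number from compound 1 to compound 3 (0.41 log units; beyond the scatter). Compound 3 is therefore estimated at 1.5 mg/kg, within 0.4 mg/kg to 6 mg/kg.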

Compound 3, dose for half-maximal effect: 75 mg/kg
For compound 3 the middle estimate is 50-fold (1.70 log units) below the measured one; measured number outside the range, above it.
By their numbers in this assay, from the lowest: compound 1; then compound 2; then compound 3.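

In this assay, the saturated chain carbon bound to a carbonyl carbon proves highly sensitive to what it carries: 4-phenylpiperazin-1-yl in place of amino gives a 130-fold higher number from compound 1 to compound 3 (2.11 log units; beyond the scatter). Among these compounds, this is the first pair differing in one place, and it shows that the much larger entering group, with its 12 heavy atoms and two rings, comes with a large rise in the dose needed. Nothing measured here explains the size of this step. Going by these compounds, whether a small amine such as dimethylamino, or piperazin-1-yl without the phenyl ring, would stay close to compound 1 remains open.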